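Trimming the Oxane Away: Expected Clearance of Compound 4

The source may hold more compounds than are shown below. What is called first, only, known or untested is meant among the compounds shown, and "the series" means these compounds.

Three closely related compounds have been measured. Compound 1 `CC(C)n1cc(-c2ccnc3[nH]c(C4CCN(CC(=O)N(C)C)CC4)cc23)cnc1=O` gives 24 uL/min in an ADME assay on microsomes from liver (Homo sapiens) for metabolic stability; a higher number here means faster removal of the compound, a lower number slower removal. Compound 2 `CN(C)C(=O)CN1CCC(c2cc3c(-c4ccc(=O)n(C5CCOCC5)c4)ccnc3[nH]2)CC1` gives 8.2 uL/min in this assay, and compound 3 `CN(C)C(=O)CN1CCC(c2cc3c(-c4ccc(=O)n(CCC5CCOCC5)c4)ccnc3[nH]2)CC1` gives 19 uL/min. Among these three numbers compound 3 stands second highest; its nearest neighbour is compound 1, within the scatter, and its furthest is compound 2, beyond the scatter. For the measured compounds named here, the one step measured so far, a 2.3-fold higher number from compound 2 to compound 3 (0.36 log units; beyond the scatter), shows that putting 2-(oxan-4-yl)ethyl in place of oxan-4-yl on an aromatic nitrogen raised the number modestly. Compound 4 `CCn1cc(-c2ccnc3[nH]c(C4CCN(CC(=O)N(C)C)CC4)cc23)ccc1=O` is reached from compound 3 by the change (hydrogen in place of oxan-4-yl on a saturated chain carbon, two bonds along the chain from an aromatic nitrogen). Going by the values given here, no measured step removes the oxan-4-yl in this way, so the step from compound 2 to compound 3 bears on it only loosely, and the direction is uncertain. Compound 4 is therefore expected to sit near compound 3, with an expected step of a 1.4-fold lower number from compound 3 to compound 4 (0.13 log units; within the scatter) and an estimate of 14 uL/min, ranging from 7 uL/min to 30 uL/min.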

Compound 4, intrinsic clearance in a liver preparation (reported as CLH), per the amount of preparation that the assay uses: < 3 uL/min
Compound 4 ended at the assay's limit; the forecaster's own chance of this, stated with the estimate: 5%; middle value at least 4.6-fold (0.66 log units) from the limit.
By their numbers in this assay, from the lowest: compound 2; then compounds 3 and 1 (each within the scatter of the next). At a limit, below all of these: compound 4.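

In this assay compound 4 stands at a limit and not at a number: the limit of < 3 uL/min in this assay, at which 1 of the 4 values shown sits.

Removing the oxan-4-yl ring gives an at least 6.3-fold lower number from compound 3 to compound 4 (0.80 log units; beyond the scatter), and ethyl in place of oxan-4-yl on the aromatic nitrogen gives an at least 2.7-fold lower number from compound 2 to compound 4 (0.43 log units; beyond the scatter), so the plain ethyl group falls under both ring-bearing groups, which the earlier step between two oxane-bearing groups could not show. The swap of the whole aromatic group on the shared core gives an at least 8.0-fold lower number from compound 1 to compound 4 (0.90 log units; beyond the scatter), a step that carries a change in ring hetero atoms and in the group on nitrogen together.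

The compounds shown leave open how far under its limit compound 4 lies. They also leave open whether a propyl chain or a 2-hydroxyethyl group on the same aromatic nitrogen would stay at that limit.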